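Notes on the series: carboxy in place of nitro

The source may hold more compounds than are shown below. What is called first, only, known or untested is meant among the compounds shown, and "the series" means these compounds.

Compound 1 `O=C(/C=C/c1ccc2c(c1)B(O)OC2)c1ccc(I)cc1` is read in a toxicity assay on MCF-10A cells (Homo sapiens) for cytotoxicity, read by MTT assay, with a stated time of 48 h; a higher number here means a weaker inhibitor, a lower number a stronger inhibitor; for compound 1 the result is a limit of the assay, > 100000 nM. Compound 2 `CCc1ccc(C(=O)/C=C/c2ccc3c(c2)B(O)OC3)cc1` in this assay gives 8800 nM, and compound 3 `O=C(/C=C/c1ccc2c(c1)B(O)OC2)c1ccc([N+](=O)[O-])cc1` gives 17500 nM. Among the numbers shown compound 3 holds the highest of two; its nearest neighbour is compound 2, and the step of a 2.0-fold higher number from compound 2 to compound 3 (0.30 log units; within the scatter) lies within the scatter. Among the compounds with values here, the only steps beyond the scatter start from the limit of compound 1: an at least 11-fold lower number from compound 1 to compound 2 (1.05 log units; beyond the scatter) and an at least 5.7-fold lower number from compound 1 to compound 3 (0.75 log units; beyond the scatter), both of which rest on (the limit of > 100000 nM in this assay, at which 1 of the 3 values shown sits).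

Compound 4 `O=C(O)c1ccc(C(=O)/C=C/c2ccc3c(c2)B(O)OC3)cc1` differs from compound 3 by carboxy in place of nitro on an aromatic carbon. Within the data shown here, no measured step involves carboxy. The two steps from compound 1 show that moving away from iodo gives a large change, while the exchange between the two numbered compounds, a 2.0-fold higher number from compound 2 to compound 3 (0.30 log units; within the scatter), stays within the scatter. On that basis no step beyond the scatter is expected in this assay for the swap to carboxy. For compound 4 in this assay the estimate is 25000 nM, with a range from 8000 nM to 80000 nM. The implied step, a 1.4-fold higher number from compound 3 to compound 4 (0.15 log units; within the scatter), is expected to stay within the scatter.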

Compound 4, half-maximal inhibitory concentration: > 100000 nM
Compound 4: only a limit was reported (the forecaster's own chance of this, stated with the estimate: 25%); middle value at least 4.0-fold (0.60 log units) from the limit.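

At this position, on an aromatic carbon para to a large group, the substituent does matter in this assay: the swap to carboxy gives an at least 5.7-fold higher number from compound 3 to compound 4 (0.75 log units; beyond the scatter) and an at least 11-fold higher number from compound 2 to compound 4 (1.05 log units; beyond the scatter) even though the exchange of ethyl for nitro stayed within the scatter. For compound 4 the reported > 100000 nM is a limit of the assay, and both steps rest on it: (the limit of > 100000 nM in this assay, at which 2 of the 4 values shown sit). The step between compound 1 and compound 4 cannot be read, so carboxy and iodo cannot be ordered here.

From the compounds shown here alone, whether a primary amide or an amine at this position would stay with compound 2 and compound 3 or reach the limit remains open. Going by these compounds, how far compound 1 and compound 4 actually lie from the limit is also open.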